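This account rests on a few compounds, and the source may have more. Where it says the series, first, only, none or still open, it means among the compounds named here.

Among the compounds with values here, compound 2, with the structure `Cc1ccc(C#Cc2ccc(C(=O)N[C@H](C)C(C)(C)O)nc2)cc1`, is one of only two compounds measured in a functional assay on HEK293 cells for positive allosteric modulation of metabotropic glutamate receptor 5 (Rattus norvegicus), read by fluorescence and calcium flux (on this read-out higher numbers stand for larger maximal responses and lower numbers for smaller maximal responses), where compound 2 reaches 63.1%. The other, compound 1, with the structure `C[C@@H](NC(=O)c1ccc(C#Cc2ccc(F)cc2F)cn1)C(C)(C)O`, reaches 61.2% in this assay, so the two numbers sit within the scatter of each other and neither can be set above the other.

Compound 3, with the structure `C[C@@H](NC(=O)c1ccc(C#Cc2cccnc2)cn1)C(C)(C)O`, is the next compound to be measured. It differs from compound 2 in one place: pyridin-3-yl in place of 4-methylphenyl on a triple-bonded carbon.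

Within the data shown here, only one measured step bears on this change. The step of a number 1.9 percentage points higher from compound 1 to compound 2 (within the scatter) also exchanged one aromatic ring for another on the very same triple-bonded carbon, and it left the maximal response unchanged within the scatter. Exchanging the 4-methylphenyl for a pyridin-3-yl at that position is therefore expected to give a step of a number 3.1 percentage points lower from compound 2 to compound 3 (within the scatter) in this assay that stays inside the scatter. On that basis, compound 3 is estimated to reach 60% in this assay, with a likely range from 42% to 78%.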

Compound 3, largest response reached (reported as efficacy), in percent of the reference or control that the assay uses: 71.5%
Beside the measured number, compound 3's estimate is 11.5 percentage points below it; the range from low to high includes it.
By their numbers in this assay, from the lowest: compounds 1, 2 and 3 (each within the scatter of the next, the first and the last beyond it).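

Within the data shown here, exchanging the 4-methylphenyl for pyridin-3-yl gives a number 8.4 percentage points higher from compound 2 to compound 3 (within the scatter) in this assay and so leaves these two compounds unranked, while exchanging the 2,4-difluorophenyl for the same ring gives a number 10.3 percentage points higher from compound 1 to compound 3 (beyond the scatter) as the first step here to clear the scatter, though only modestly. The earlier compounds shown here carried only carbon rings on the triple-bonded carbon, whereas compound 3 shows that a ring with a nitrogen atom and one hydrogen-bond acceptor can sit there without any loss of maximal response, and that a change at this position can move the response beyond the scatter. No measurement here explains the difference between these rings.

Compound 3 differs from compounds 1 and 2 both by its ring nitrogen and by lacking their fluorine or methyl substituents, so the compounds shown cannot tell which of these matters. A plain phenyl on the same triple-bonded carbon would help separate the two, and a pyridin-4-yl or pyridin-2-yl would show whether the place of the nitrogen within the ring counts.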